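This account rests on a few compounds, and the source may have more. Where it says the series, first, only, none or still open, it means among the compounds named here.

Measured in a physicochemical assay for solubility, in phosphate buffer, with a stated time of 18 h; on this read-out higher numbers stand for higher solubility and lower numbers for lower solubility:
- compound 1 `CC(C)(C)c1nc(-c2ccc[nH]2)c2cc(C(N)=O)c(N)nc2n1` gives 130000 nM
- compound 2 `CC(C)c1ncc2c(N)c(C#N)c(N)nc2n1` gives > 1000000 nM (a limit of the assay)
- compound 3 `N#Cc1c(N)nc2nc(C3CCC3)ncc2c1N` gives 217000 nM

Only two of these results are actual numbers. Compound 1 at 130000 nM and compound 3 at 217000 nM lie within the scatter of each other. Compound 2 stands at > 1000000 nM, which is a limit and not a number.

Compound 4 `N#Cc1c(N)nc2nc(C3CCCCC3)ncc2c1N` has cyclohexyl in place of cyclobutyl on an aromatic carbon of the shared core: cyclohexyl in place of cyclobutyl on an aromatic carbon. Going by the values given here, only one measured step bears on this change, and it concerns the same place: an at least 4.6-fold lower number from compound 2 to compound 3 (0.66 log units; beyond the scatter). From the compounds shown here alone, its true size remains open because of the limit of > 1000000 nM in this assay, at which 1 of the 3 values shown sits. Among the compounds with values here, compound 1 differs from compound 3 in more than one place and offers no step here.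

From the step to compound 3, a change of similar size toward a lower number is expected in this assay, beyond the scatter, though a single step is thin ground. For compound 4 the estimated value is 55000 nM, with an expected range from 12000 nM to 200000 nM. This is an expected 3.9-fold lower number from compound 3 to compound 4 (0.60 log units; beyond the scatter).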

Compound 4, solubility: 81000 nM
The estimate for compound 4 lay 1.5-fold (0.17 log units) below the measured number; the range from low to high includes it.
By their numbers in this assay, from the lowest: compounds 4, 1 and 3 (each within the scatter of the next, the first and the last beyond it). At a limit, above all of these: compound 2.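

In this assay, the aromatic carbon between two ring nitrogen atoms now carries a third group, and a 2.7-fold lower number from compound 3 to compound 4 (0.43 log units; beyond the scatter) shows that the number falls again when cyclohexyl replaces cyclobutyl. Across isopropyl, cyclobutyl and cyclohexyl, the three compounds with this shared core all run the same way, and the full span is an at least 12-fold lower number from compound 2 to compound 4 (1.09 log units; beyond the scatter). Compound 2 is given only as a limit and not a number, so the true size of that span stays open: the limit of > 1000000 nM in this assay, at which 1 of the 4 values shown sits.

From the compounds shown here alone, all three groups at this position are built of carbon only, so it remains open what an amine or a carboxylic acid there would give, or whether a longer chain would continue the fall. Compound 1 differs from compound 3 in more than one place and adds nothing on this change.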